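The compounds below may be only part of what the source reports. "The series", "measured", "known", "first", "only" and "open" are said of these compounds alone.

In a functional assay on SW480 cells (Homo sapiens) for antiproliferative activity, read by MTT assay, with a stated time of 48 h (on this read-out lower numbers stand for stronger inhibition and higher numbers for weaker inhibition), compound 1 `CCCCC(CCO)n1cnc2c(Cl)nc(Cl)nc21` gives 30900 nM, while compound 2 `CCCCCCCCCC(CCO)n1cnc2c(Cl)ncnc21` gives 1150 nM, the lower of the two numbers, with a gap beyond the usual scatter. Compound 3 `CCCCCCCCCC(CCO)n1cnc2c(Cl)nc(Cl)nc21` is compound 2 with one change: chloro in place of hydrogen on an aromatic carbon. Among the compounds with values here, compound 1 and compound 2 differ in more than one place, so no measured pair isolates this change. In this assay no step beyond the scatter is expected, and the estimated step is a 1.3-fold higher number from compound 2 to compound 3 (0.12 log units; within the scatter). For compound 3 the estimated value is 1500 nM, with an expected range of 500 nM to 4500 nM.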

Compound 3, half-maximal inhibitory concentration: 36300 nM
Compound 3: middle estimate off by 24-fold (1.38 log units), on the low side; measured number above the stated range.
By their numbers in this assay, from the lowest: compound 2; then compounds 1 and 3 (each within the scatter of the next).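

In this assay, this aromatic carbon between two ring nitrogen atoms proves sensitive: with the long chain kept, chloro in place of hydrogen brings a 32-fold higher number from compound 2 to compound 3 (1.50 log units; beyond the scatter) and so a clear loss of inhibition. With chloro on this carbon, adding pentyl to the chain gives a 1.2-fold higher number from compound 1 to compound 3 (0.07 log units; within the scatter) and so no real difference. Nothing available explains the loss.
From the compounds shown here alone, whether an amine or a methoxy group on this carbon would behave like hydrogen or like chloro stays open. So does whether a longer chain would alter either result.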